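The source may hold more compounds than are shown below. What is called first, only, known or untested is meant among the compounds shown, and "the series" means these compounds.

Going by the values given here, compound 1 `CCOC(=O)CO/N=C(\C)c1ccc(Sc2cc(F)cc(C3CCOCC3)c2)cc1` is one of two compounds measured in a functional assay (blood) for inhibition, with Homo sapiens as the target (on this read-out higher numbers stand for weaker inhibition and lower numbers for stronger inhibition), and in it compound 1 gives 610 nM as the highest of the two numbers. Among the compounds with values here, compound 2 `C/C(=N\OCCSc1nnnn1C)c1ccc(Sc2cc(F)cc(C3CCOCC3)c2)cc1` gives 120 nM in this assay and the single measured step, a 5.1-fold lower number from compound 1 to compound 2 (0.71 log units; beyond the scatter), came from exchanging the end of the chain that hangs off the oxygen. Compound 3 `O/N=C(/c1ccc(Sc2cc(F)cc(C3CCOCC3)c2)cc1)C(F)(F)F` differs from compound 1 in this way: a group of 7 heavy atoms (2 carbon, 1 nitrogen, 1 oxygen, 3 fluorine; no ring) in place of a group of 10 heavy atoms (6 carbon, 1 nitrogen, 3 oxygen; no ring), on an aromatic carbon. That step touched the same part of the molecule, but it added a larger group, whereas compound 3 loses the chain altogether and carries trifluoromethyl in place of methyl, so the measured step does not transfer directly. Within the data shown here, with no step bearing on trifluoromethyl the direction is open, and the step of a 1.2-fold lower number from compound 1 to compound 3 (0.09 log units; within the scatter) is expected to be small. Compound 3 is therefore estimated at 500 nM with a range from 150 nM to 2000 nM in this assay.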

Compound 3, half-maximal inhibitory concentration: 280 nM
Estimate against measurement, compound 3: 1.8-fold (0.25 log units) above, within the range that was stated.
By their numbers in this assay, from the lowest: compound 2; then compound 3; then compound 1.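

In this assay the step to the shorter group gives a 2.2-fold lower number from compound 1 to compound 3 (0.34 log units; beyond the scatter) and so goes toward stronger inhibition, which shows that the ethoxycarbonyl chain on the oxygen is not needed for inhibition at this level. Unlike the earlier step, which only exchanged the end of that chain, this change removes the chain and also puts trifluoromethyl in place of methyl, so the result cannot be divided between these two edits. Nothing measured here accounts for the size or direction of this step.

The compounds shown leave open how much of the step belongs to the trifluoromethyl and how much to the loss of the chain. Also open, on these data alone, is how a carboxylic acid or an amine at the end of the chain would read out on the same core.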